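The source may report more compounds than this note shows. Statements on the series, on what has been measured and on what is new or still open speak of the compounds shown alone.

Compound 1, `COc1nc2ccc(Br)cc2cc1C(c1ccccc1)n1cc(-c2ccc(OC(F)(F)F)cc2)nn1`, gives 11.7% in an ADME assay on PANC-1 cells (Homo sapiens) for cytotoxicity, read by sulforhodamine B assay, with a stated time of 48 h, tested at 10 uM; on this read-out lower numbers stand for less inhibition and higher numbers for more inhibition at the one concentration tested (going by the name of the read-out). Compound 2, `COc1nc2ccc(Br)cc2cc1C(c1ccccc1)n1cc(CO)nn1`, gives 15% in this assay. Compound 3, `CCCc1cn(C(c2ccccc2)c2cc3cc(Br)ccc3nc2OC)nn1`, gives 11.3% in this assay.

On these three numbers compound 1 holds the second highest place, yet both of its neighbours sit close: the step of a number 0.4 percentage points lower from compound 1 to compound 3 (within the scatter) and the step of a number 3.3 percentage points higher from compound 1 to compound 2 (within the scatter) each stay within the scatter, as does the step of a number 3.7 percentage points lower from compound 2 to compound 3 (within the scatter). All three measured compounds share the same core and differ only in the group carried on the five-membered aromatic ring, and none of those exchanges has shifted the read-out by more than the scatter.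

Compound 4, `COc1nc2ccc(Br)cc2cc1C(c1ccccc1)n1cc(-c2ccccc2C(F)(F)F)nn1`, departs from compound 1 by one change: 2-(trifluoromethyl)phenyl in place of 4-(trifluoromethoxy)phenyl on an aromatic carbon. Among the measured compounds shown here, the steps that bear on it are those from compound 1 to compound 3 and from compound 1 to compound 2, where other groups replaced the same 4-(trifluoromethoxy)phenyl and the numbers barely moved. The expectation for this assay is therefore no step beyond the scatter, in either direction, and the estimated step is a number 0.3 percentage points higher from compound 1 to compound 4 (within the scatter). Compound 4 is expected to give 12%, within a range from 3% to 22%.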

Compound 4, a percentage reported as inhibition, at one concentration (the size of the read-out at that concentration, not a potency): 11.4%
The estimate for compound 4 lay 0.6 percentage points above the measured number, within the range that was stated.
By their numbers in this assay, from the lowest: compounds 3, 4, 1 and 2 (each within the scatter of the next).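

In this assay the exchange of 4-(trifluoromethoxy)phenyl for 2-(trifluoromethyl)phenyl on this aromatic carbon of the five-membered ring gives a number 0.3 percentage points lower from compound 1 to compound 4 (within the scatter) and the same group gives a number 0.1 percentage points higher from compound 3 to compound 4 (within the scatter) against propyl and a number 3.6 percentage points lower from compound 2 to compound 4 (within the scatter) against hydroxymethyl as its other steps. The earlier compounds held only one substituted phenyl group here; a second one, with a different fluorinated substituent, also stays within the scatter of all three, so the four groups shown cannot be told apart at this one concentration. Nothing measured here offers an explanation for this result. The compounds shown leave open whether an amine, a carboxylic acid or a longer chain on this carbon would give a step beyond the scatter. They also leave open whether changes elsewhere on the shared core would do so.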